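Swapping the Carbamate for a Cyclohexylmethyl Chain

A few compounds are considered here, and "the series" means these few. Any claim that something is new, unique, unknown or untested is made for them only; others in the source may bear on it.

Measured so far:
- Compound 1, `Cc1cccc(C)c1NC(=O)Nc1ccc2nc(NC(=O)C3CCCCC3)sc2c1`: 0.56 ug/mL
- Compound 2, `CCOC(=O)Nc1nc2ccc(NC(=O)c3c(Cl)cccc3Cl)cc2s1`: 0.0026 ug/mL

Of the compounds shown here, two sharing the same core have been tested in a functional assay on WI-38 VA13 cells (Homo sapiens) for cytotoxicity; on this read-out lower numbers stand for an effect already at smaller amounts and higher numbers for an effect only at larger amounts of compound. Compound 1 `Cc1cccc(C)c1NC(=O)Nc1ccc2nc(NC(=O)C3CCCCC3)sc2c1` gives 0.56 ug/mL in this assay. Compound 2 `CCOC(=O)Nc1nc2ccc(NC(=O)c3c(Cl)cccc3Cl)cc2s1` gives 0.0026 ug/mL in this assay, the lowest of the two numbers; its gap to compound 1 lies well beyond the usual scatter, so compound 2 acts at clearly smaller amounts.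

Compound 3 `O=C(Nc1ccc2nc(NCC3CCCCC3)sc2c1)c1c(Cl)cccc1Cl` has not yet been measured. It differs from compound 2 in one place:

cyclohexylmethyl in place of ethoxycarbonyl on a nitrogen on an aromatic ring

The cyclohexylmethyl group has no hydrogen-bond acceptors, whereas the ethoxycarbonyl group it replaces has two, and the carbonyl at that nitrogen disappears. For the measured compounds named here, no measured pair shows this exact change, so the direction can only be estimated. Because compound 2 already sits at 0.0026 ug/mL, there is far more room upward than downward. Compound 3 is expected to give about 0.1 ug/mL in this assay, within a range from 0.01 ug/mL to 1 ug/mL, which amounts to an expected step of a 38-fold higher number from compound 2 to compound 3 (1.59 log units; beyond the scatter).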

Compound 3, half-maximal effective concentration: 4.3 ug/mL
For compound 3 the middle estimate is 43-fold (1.63 log units) below the measured one, and the stated range ends below it.
By their numbers in this assay, from the lowest: compound 2; then compound 1; then compound 3.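

In this assay the group on this nitrogen on an aromatic ring proves decisive: cyclohexylmethyl in place of ethoxycarbonyl gives a 1700-fold higher number from compound 2 to compound 3 (3.22 log units; beyond the scatter), a large step that lies beyond the scatter. Compound 1 and compound 2 differ in more than one place, so their values could not tie any change to a single site, whereas this pair keeps everything else fixed and places the whole shift on this one swap. No measurement at hand explains the size of this step.

The swap removes the carbonyl and two hydrogen-bond acceptors and brings in a six-membered ring of carbon in a single move, so the compounds shown cannot tell which of these differences carries the step. Intermediate groups on the same nitrogen, such as acetyl, methoxycarbonyl, a plain cyclohexanecarbonyl or the free amine, could begin to separate those differences, and how far the number would then move in either direction remains open.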